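The compounds below may be only part of what the source reports. "The series", "measured", "known", "first", "only" and "open" are said of these compounds alone.

Working notes on the series in an assay on isolated protein for agonist activity at Bile acid receptor (Homo sapiens), read by TR-FRET, with a stated time of 3 h, in the absence of a further agent; a higher number here means that more compound is needed for the effect, a lower number that less compound is needed. The three measured compounds share an anilide core with a carboxylic acid on the aniline side and an ether on the benzoyl side. Compound 1 `O=C(O)c1ccc(NC(=O)c2ccc(Oc3ccccc3)cc2)cc1` returns only the assay limit, > 10000 nM. Compound 2 `CC(Oc1cccc(NC(=O)c2ccc(Oc3ccccc3)cc2)c1)C(=O)O` likewise returns a limit, > 10000 nM. Among the compounds with values here, compound 3 `CC(C)COc1ccc(C(=O)Nc2cccc(C(=O)O)c2)cc1` is the sole member with a measured number, 357 nM, and therefore the only point of reference; the two remaining values sit at the limit of > 10000 nM in this assay, at which 2 of the 3 values shown sit, so no step between measured compounds can be read from them.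

Compound 4 `CO/N=C(/COc1ccc(C(=O)Nc2cccc(C(=O)O)c2)cc1)c1ccccc1` differs from compound 3 in a single place: a group of 10 heavy atoms (8 carbon, 1 nitrogen, 1 oxygen; one six-membered aromatic ring of carbon only) in place of a group of 3 heavy atoms (3 carbon; no ring), on a saturated chain carbon bound to an oxygen on an aromatic ring. Within the data shown here, nothing among the measured compounds calibrates a change of this kind, since the two limits carry no direction and compound 3 stands alone. The expectation rests only on the fact that compound 3 already gives a number where the others do not, and a step beyond the usual scatter toward a lower concentration is expected from compound 3 to compound 4, a 2.4-fold lower number from compound 3 to compound 4 (0.38 log units; beyond the scatter). Compound 4 is accordingly estimated at 150 nM in this assay. The expected range for compound 4 runs from 30 nM to 800 nM.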

Compound 4, half-maximal effective concentration: > 10000 nM
Compound 4: a limit, no number; the forecaster's own chance of this, stated with the estimate: 10%; middle value at least 66-fold (1.82 log units) away from the limit.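

At the saturated chain carbon bound to an oxygen on an aromatic ring, replacing isopropyl with the group of compound 4 gives an at least 28-fold higher number from compound 3 to compound 4 (1.44 log units; beyond the scatter). Within the data shown here, this is the first step that can be read, and it shows that the number seen for compound 3 in this assay does not survive every change at this place, something the earlier limits could not show. Compound 3 therefore remains the only compound with a measured number, and compound 4 now joins compounds 1 and 2 at the limit: the limit of > 10000 nM in this assay, at which 3 of the 4 values shown sit.

The entering group differs from isopropyl at once in its size, its aromatic ring, its double bond and its hydrogen-bond acceptors, so this single step does not show which of these features goes with the loss of a measured number. As far as these compounds go, it also remains open whether a cyclopropyl, a plain phenyl on the same chain carbon or a longer alkyl chain would keep a measured number at this place, and how such a group would compare with isopropyl.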